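Swapping a Carboxyethyl Amide for a Hydroxypiperidine Amide

This account rests on a few compounds, and the source may have more. Where it says the series, first, only, none or still open, it means among the compounds named here.

Three compounds share one core and differ only in the group carried on the amide that hangs off it. Compound 1 `CC(C)(C)OC(=O)NCCCCCNC(=O)CN1CN(c2ccccc2)C2(CCN(C(=O)c3ccc(C(C)(C)C)cc3)CC2)C1=O` and compound 2 `CC(C)(C)c1ccc(C(=O)N2CCC3(CC2)C(=O)N(CC(=O)NCCC(=O)O)CN3c2ccccc2)cc1` were measured in an assay on HEK293 cells for displacement of a labelled ligand from NPC1-like intracellular cholesterol transporter 1 (Homo sapiens); a higher number here means a weaker inhibitor, a lower number a stronger inhibitor; for compound 3 `CC(C)(C)OC(=O)NCCCCNC(=O)CN1CN(c2ccccc2)C2(CCN(C(=O)c3ccc(C(C)(C)C)cc3)CC2)C1=O` the entry in this assay reads "not determined" (no result reported). In this assay compound 1 gives 13700 nM, and compound 2 gives 11400 nM. Both numbers mean weak binding, and the step between them, a 1.2-fold lower number from compound 1 to compound 2 (0.08 log units; within the scatter), lies within the scatter of the measurement. Of the two numbers, compound 2 has the lower one, with compound 1 nearest, and the gap between them is within the scatter.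

Compound 4 `CC(C)(C)c1ccc(C(=O)N2CCC3(CC2)C(=O)N(CC(=O)N2CCCC(O)C2)CN3c2ccccc2)cc1` is the next candidate. 3-hydroxypiperidin-1-yl in place of (2-carboxyethyl)amino on a carbonyl carbon The open chain that leaves, with its carboxy end, gives way to a six-membered ring bearing a hydroxy group. Among the measured compounds shown here, the only measured step, a 1.2-fold lower number from compound 1 to compound 2 (0.08 log units; within the scatter), concerned a different exchange at the chain end and moved the number hardly at all; nothing else measured bears on a ring in this place. The expectation is therefore a step no larger than the scatter, with no preferred direction, so the estimated step is a 1.0-fold lower number from compound 2 to compound 4 (0.02 log units; within the scatter). Compound 4 is expected to give about 11000 nM in this assay, within a range of 3500 nM to 35000 nM.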

Compound 4, half-maximal inhibitory concentration: 12200 nM
The estimate for compound 4 lay 1.1-fold (0.04 log units) below the measured number; the measured number falls inside the stated range.
By their numbers in this assay, from the lowest: compounds 2, 4 and 1 (each within the scatter of the next).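

In this assay, the exchange on this carbonyl carbon gives a 1.1-fold higher number from compound 2 to compound 4 (0.03 log units; within the scatter), so the two compounds cannot be told apart. Among the compounds shown here, this is the first ring at this place: the open chain with its carboxy end can give way to 3-hydroxypiperidin-1-yl with no step beyond the scatter, so neither the carboxy group nor the open chain shows up as a requirement for the weak binding seen here, and compound 1 at 13700 nM and compound 4 at 12200 nM carry very different groups yet give numbers of the same order. No measurement here offers an explanation for this flat result.

Going by these compounds, what remains open is whether the hydroxy group of compound 4 matters at all, which a plain piperidin-1-yl amide, with the ring but without the hydroxy group, would help to settle. On these data alone, it is also open whether any group on this carbonyl carbon can give a number clearly lower than these, for instance a chain ending in a basic amine, such as 2-aminoethylamino.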